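Chloro for amino on the purine core: compound 4

This account rests on a few compounds, and the source may have more. Where it says the series, first, only, none or still open, it means among the compounds named here.

Compound 3 `Nc1nc(Cl)c2ncn(Cc3ccc(CCl)cc3)c2n1` gives 8320 nM in a functional assay on SF-268 cells (Homo sapiens) for cytotoxicity, read by sulforhodamine B assay, with a stated time of 48 h; on this read-out higher numbers stand for weaker inhibition of growth and lower numbers for stronger inhibition of growth; this is the highest of the three numbers, but its nearest neighbour, compound 2 `ClCc1ccccc1Cn1cnc2c(Cl)nc(Cl)nc21` with 4160 nM, lies within the scatter of it, and only compound 1 `ClCc1ccc(Cn2cnc3c(Cl)ncnc32)cc1` with 2880 nM is beyond it. The step to compound 4 `ClCc1ccc(Cn2cnc3c(Cl)nc(Cl)nc32)cc1` is chloro in place of amino on an aromatic carbon. Within the data shown here, no measured pair shows chloro replacing amino. Among the measured compounds shown here, the one step at this position is a 2.9-fold higher number from compound 1 to compound 3 (0.46 log units; beyond the scatter), so taking the amino away again should roughly recover the number of compound 1; what the entering chloro adds is not covered by any step. Compound 2 carries the same two chloro groups as compound 4 with the chloromethyl in a different place, and its value sits between compound 1 and compound 3. Compound 4 is therefore expected near compound 1 and compound 2, a step of a 2.4-fold lower number from compound 3 to compound 4 (0.38 log units; beyond the scatter) in this assay, towards stronger growth inhibition. The estimate for compound 4 is 3500 nM, within 1500 nM to 8000 nM.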

Compound 4, concentration for total growth inhibition: 5370 nM
Estimate against measurement, compound 4: 1.5-fold (0.19 log units) below; the range from low to high includes it.
By their numbers in this assay, from the lowest: compounds 1, 2, 4 and 3 (each within the scatter of the next, the first and the last beyond it).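

Chloro now gives a third substituent on the aromatic carbon between two ring nitrogen atoms, and in this assay it cannot be separated from either of the other two: a 1.5-fold lower number from compound 3 to compound 4 (0.19 log units; within the scatter) and a 1.9-fold higher number from compound 1 to compound 4 (0.27 log units; within the scatter). Only hydrogen and amino are resolved at this position, with a 2.9-fold higher number from compound 1 to compound 3 (0.46 log units; beyond the scatter), so chloro does not sit clearly with either group, and the change from amino to chloro brings no measurable gain in growth inhibition. No supporting evidence bears on this result.

As far as these compounds go, whether a methoxy or dimethylamino group on this carbon would move the number beyond the scatter remains open. From the compounds shown here alone, all four compounds carry the chloromethyl group, so what a plain methyl in its place would do to the growth-inhibition read-out also remains open.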